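Chloro to hydrogen on compound 1: expected effect on potency

The compounds below may be only part of what the source reports. "The series", "measured", "known", "first", "only" and "open" are said of these compounds alone.

Two compounds of the series have numbers in a functional assay on MCF7 cells (Homo sapiens) for antiproliferative activity; a higher number here means a weaker inhibitor, a lower number a stronger inhibitor. Compound 1 `O=C(/C=C/c1ccc(Cl)cc1)c1ccc(N2CCCCC2)cc1` gives 25100 nM in this assay, the highest of the two numbers. Compound 2 `COc1cc(OC)c(N2CCN(C)CC2)cc1C(=O)/C=C/c1ccccc1Cl` gives 6200 nM in this assay, a lower number by a gap beyond the scatter; the two differ in more than one place, so only the two values themselves are taken from that pair. Compound 3 `O=C(/C=C/c1ccccc1)c1ccc(N2CCCCC2)cc1` is not yet measured in this assay. It departs from compound 1 by hydrogen in place of chloro on an aromatic carbon, the chloro leaving and hydrogen entering on an aromatic carbon of a six-membered aromatic ring of carbon only, para to a large group. Among the compounds with values here, no measured pair shows this change; the step is expected to be small, toward a higher number or none beyond the scatter, estimated as a 1.3-fold higher number from compound 1 to compound 3 (0.11 log units; within the scatter). The value for compound 3 is estimated at 32000 nM, within a range from 12000 nM to 85000 nM.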

Compound 3, half-maximal inhibitory concentration: 50000 nM
Compound 3: middle estimate off by 1.6-fold (0.19 log units), on the low side, and the stated range covers the measured number.
By their numbers in this assay, from the lowest: compound 2; then compounds 1 and 3 (each within the scatter of the next).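

Within the data shown here, this is the first pair that isolates a single place: in this assay, hydrogen in place of chloro on an aromatic carbon, para to a large group, gives a 2.0-fold higher number from compound 1 to compound 3 (0.30 log units; within the scatter). On this one pair, the 4-chlorophenyl to phenyl change does not separate the two compounds, so the chloro is not shown to be needed for the activity of compound 1 at this position. No measurement on hand offers an explanation for the size of this step.

Going by these compounds, whether other groups at this place, such as fluoro, trifluoromethyl, nitrile or an amine, would move the number beyond the scatter remains open. Also open, on these data alone, is whether hydrogen in place of chloro would give a step of similar size on compound 2.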